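This account rests on a few compounds, and the source may have more. Where it says the series, first, only, none or still open, it means among the compounds named here.

Measured compounds and their values:
compound 1, `CCCCCCCCCO[C@@H]1[C@@H](N)[C@@H](OCC(O)CNCCN)O[C@H](CN)[C@H]1OCCCCCCCCC`, gives 87.5% in a toxicity assay on the whole organism (J774 cells) for cytotoxicity, with Mus musculus as the target, read by MTT assay, with a stated time of 24 h, tested at 10 uM; on this read-out higher numbers stand for a weaker effect at the one concentration tested and lower numbers for a stronger effect;
compound 2, `NC[C@H]1O[C@H](O[C@H]2[C@H](O)[C@@H](O)[C@H](N)C[C@@H]2N)[C@H](N)[C@@H](OCc2ccc3ccccc3c2)[C@@H]1OCc1ccc2ccccc2c1`, gives 79.1%;
compound 3, `CCCCCCCCCO[C@@H]1[C@@H](N)[C@@H](OCC(O)CNCCCN)O[C@H](CN)[C@H]1OCCCCCCCCC`, gives 101%.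

On these numbers, compound 2 and compound 1 lie within the scatter of each other in this assay, while compound 3 stands higher than compound 2, beyond the scatter. Compound 4, `C=CCO[C@H]1O[C@H](CN)[C@@H](OCc2ccc3ccccc3c2)[C@H](OCc2ccc3ccccc3c2)[C@H]1N`, differs from compound 2 by allyl in place of 4,6-diamino-2,3-dihydroxycyclohexyl on an oxygen on a saturated carbon. Within the data shown here, the only measured step, a number 13.5 percentage points higher from compound 1 to compound 3 (beyond the scatter), concerns a different change on a different pair and does not bear on this one. Among the measured compounds shown here, with no comparable step among the measured compounds, no step beyond the scatter is expected from compound 2 to compound 4, but with wide uncertainty. Compound 4 is therefore expected to give 80%, within 55% to 100%. That corresponds to an expected step of a number 0.9 percentage points higher from compound 2 to compound 4 (within the scatter).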

Compound 4, a percentage reported as activity, at one concentration (the size of the read-out at that concentration, not a potency): 86.9%
Compound 4: the middle estimate sits 6.9 percentage points below what was measured, within the range that was stated.
By their numbers in this assay, from the lowest: compounds 2, 4 and 1 (each within the scatter of the next); then compound 3.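

At this oxygen, the large 4,6-diamino-2,3-dihydroxycyclohexyl group can give way to the much smaller allyl, with its lack of a ring and of hydrogen-bond donors, and this assay shows only a number 7.8 percentage points higher from compound 2 to compound 4 (within the scatter). Among these compounds, the earlier compounds held no comparison at this place, so this is the first sign that the read-out stays within the scatter across so large a change. No measurement shown gives a reason for this result.

Going by these compounds, whether this holds for other groups on the same oxygen stays open. A methyl group or a carboxylic acid there could still give a different reading.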